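The source may report more compounds than this note shows. Statements on the series, on what has been measured and on what is new or still open speak of the compounds shown alone.

Measured so far:
compound 1, `CN(C)CC(=O)N1CCC[C@H]1C(=O)N1CCC(NS(=O)(=O)c2cc(S(=O)(=O)c3ccccc3)ccc2C(F)(F)F)CC1` — 310 nM
compound 2, `CN(C)C(=O)N1CCC[C@H]1C(=O)N1CCC(NS(=O)(=O)c2cc(S(=O)(=O)c3ccccc3)ccc2C(F)(F)F)CC1` — 160 nM

Among the compounds with values here, in a functional assay on U2OS cells for antagonist activity at proto-oncogene Wnt-3 (Homo sapiens), read by a luciferase reporter, with a stated time of 18 h (on this read-out lower numbers stand for an effect already at smaller amounts and higher numbers for an effect only at larger amounts of compound), compound 2 gives the lowest of the two numbers, with compound 1 as its only neighbour; the difference a 1.9-fold lower number from compound 1 to compound 2 (0.29 log units; within the scatter) lies within the scatter, so the two values are not told apart. Compound 3, `O=C([C@@H]1CCCN1Cc1ccccc1)N1CCC(NS(=O)(=O)c2cc(S(=O)(=O)c3ccccc3)ccc2C(F)(F)F)CC1`, differs from compound 2 by benzyl in place of dimethylcarbamoyl on an amine nitrogen in a ring. Within the data shown here, the single measured step, a 1.9-fold lower number from compound 1 to compound 2 (0.29 log units; within the scatter), concerns an exchange on a carbonyl carbon and keeps the carbonyl in place; it does not touch the change that compound 3 brings, in which the carbonyl leaves and an aromatic ring enters on the amine nitrogen. Among the measured compounds shown here, no measured step therefore bears on this change. With nothing to point either way, compound 3 is expected to stay near compound 2, the estimated step of a 1.9-fold higher number from compound 2 to compound 3 (0.27 log units; within the scatter) being uncertain in direction. The estimate for compound 3 in this assay is 300 nM, with a range from 70 nM to 1300 nM.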

Compound 3, half-maximal effective concentration: 720 nM
For compound 3 the middle estimate is 2.4-fold (0.38 log units) below the measured one, and the stated range covers the measured number.
By their numbers in this assay, from the lowest: compounds 2 and 1 (each within the scatter of the next); then compound 3.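

In this assay, the amine nitrogen of the five-membered ring now shows a change beyond the scatter: benzyl gives a 4.5-fold higher number from compound 2 to compound 3 (0.65 log units; beyond the scatter) and, against the longer acyl group, a 2.3-fold higher number from compound 1 to compound 3 (0.37 log units; beyond the scatter), both modest steps. Within the data shown here, the two groups that keep a carbonyl on this nitrogen could not be told apart, so compounds 1 and 2 alone gave no sign that the position responds to what it carries, whereas compound 3, the one compound here without that carbonyl, gives the highest number. Nothing available explains this shift.

The step swaps a carbonyl-bearing group for an aromatic ring in one move, so the loss of the one and the arrival of the other remain unseparated. A benzoyl group, which holds both, or a plain methyl, which holds neither, would pull them apart.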